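The source may hold more compounds than are shown below. What is called first, only, known or untested is meant among the compounds shown, and "the series" means these compounds.

Measured compounds:
- compound 1 `CCN(CC)CCCNc1nc(-c2ccc(NC(=O)Nc3ccc(Cl)cc3)cc2)nc2c(Cl)c(Cl)sc12`, which in a functional assay on HT-29 cells (Homo sapiens) for cytotoxicity, read by MTT assay, with a stated time of 72 h (on this read-out higher numbers stand for weaker inhibition and lower numbers for stronger inhibition), gives 250 nM
- compound 2 `CCN(CC)CCCNc1nc(-c2ccc(NC(=O)Nc3ccc(Cl)cc3Cl)cc2)nc2c(Cl)c(Cl)sc12`, which in this assay gives 1230 nM

Among the compounds with values here, of the two numbers in hand, compound 2 gives the higher one, and the only step recorded is a 4.9-fold higher number from compound 1 to compound 2 (0.69 log units; beyond the scatter), where the difference is a chloro in place of hydrogen on an aromatic carbon of the urea-linked phenyl group.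

Compound 3 `CCN(CC)CCCNc1nc(-c2ccc(NC(=O)Nc3ccc(C)cc3)cc2)nc2c(Cl)c(Cl)sc12` has not yet been tested in this assay. It differs from compound 2 in one place: 4-methylphenyl in place of 2,4-dichlorophenyl on an amide-type nitrogen. This change removes the chloro whose entry made the step from compound 1 to compound 2 a modest weakening, and it also exchanges the remaining chloro for methyl. Only the first part of that change has a measured counterpart; nothing in hand speaks to methyl in place of chloro on this ring. Within the data shown here, on the strength of the one step that bears on it, compound 3 is expected to move back toward compound 1, giving an expected step of a 4.1-fold lower number from compound 2 to compound 3 (0.61 log units; beyond the scatter). The estimate for compound 3 in this assay is therefore 300 nM, with a range from 100 nM to 1000 nM.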

Compound 3, half-maximal inhibitory concentration: 890 nM
Estimate against measurement, compound 3: 3.0-fold (0.47 log units) below; the range from low to high includes it.
By their numbers in this assay, from the lowest: compound 1; then compounds 3 and 2 (each within the scatter of the next).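

In this assay, the change to 4-methylphenyl on the amide-type nitrogen gives a 1.4-fold lower number from compound 2 to compound 3 (0.14 log units; within the scatter), so compound 3 cannot be told apart from compound 2 even though one chloro has gone and the other has become methyl. Within the data shown here, the exchange of methyl for chloro, which no earlier pair covered, gives a 3.6-fold higher number from compound 1 to compound 3 (0.55 log units; beyond the scatter) and is therefore a modest weakening that can be read on its own; with a 4.9-fold higher number from compound 1 to compound 2 (0.69 log units; beyond the scatter) as well, both changes made to this ring of compound 1 lead to a higher number, and neither compound 2 nor compound 3 goes against this among the three compounds. Nothing available explains either step.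

The compounds shown leave open whether any other group in place of the chloro of compound 1, such as fluoro, methoxy, trifluoromethyl or an amine, would hold its number or lower it. They also leave open how a plain phenyl group on the amide-type nitrogen would compare, and so whether the chloro of compound 1 helps at all or merely does less harm than methyl.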